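This account rests on a few compounds, and the source may have more. Where it says the series, first, only, none or still open, it means among the compounds named here.

In a functional assay on A549 cells (Homo sapiens) for antiproliferative activity, read by MTT assay, with a stated time of 72 h (on this read-out higher numbers stand for weaker inhibition and lower numbers for stronger inhibition), two compounds sharing one core have been measured so far. Compound 1 `COc1cc(-n2cnc3ccc(-c4ccc(C)cc4F)cc32)cc(OC)c1OC` gives > 10000 nM as its reading, which is a limit of the assay and not a number. Compound 2 `COc1cc(-n2cnc3ccc(-c4ccc(Cl)cc4Cl)cc32)cc(OC)c1OC` gives > 10000 nM as its reading, again a limit and not a number. Compound 2 therefore has no exact place on the scale. For the measured compounds named here, the one measured change is a step that the two limits leave unreadable from compound 1 to compound 2 and so offers no size to build on. The next change is 4-methoxyphenyl in place of 2,4-dichlorophenyl on an aromatic carbon and it leads to compound 3 `COc1ccc(-c2ccc3ncn(-c4cc(OC)c(OC)c(OC)c4)c3c2)cc1` with the shared core left as it was. In words, 4-methoxyphenyl takes the place of 2,4-dichlorophenyl on an aromatic carbon. For compound 2 the evidence is the limit of > 10000 nM in this assay, at which 2 of the 2 values shown sit, so only a modest move toward stronger inhibition is expected, and a reading that stays at the limit would be no surprise. The step expected is an at least 3.3-fold lower number from compound 2 to compound 3 (0.52 log units; beyond the scatter) and it remains an estimate. The estimated value for compound 3 is 3000 nM with an expected range from 300 nM to 10000 nM around it.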

Compound 3, half-maximal inhibitory concentration: > 10000 nM
Compound 3 gave a limit, no number; the forecaster's own chance of this, stated with the estimate: 45%; middle value at least 3.3-fold (0.52 log units) from the limit.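

For the compounds shown here, compound 3 also gives a limit and not a number, so no step among compound 1, compound 2 and compound 3 can be read in this assay: the limit of > 10000 nM in this assay, at which 3 of the 3 values shown sit. The compounds shown leave open whether any group at this place on the shared core would give a reading that is an actual number.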